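Dimethylamino in place of bromo: expected cytotoxicity of compound 4

The compounds below may be only part of what the source reports. "The series", "measured", "known", "first", "only" and "open" are said of these compounds alone.

Measured compounds in a functional assay on cells (Homo sapiens) for cytotoxicity; a higher number here means that more compound is tolerated, a lower number that less compound is tolerated:
- compound 1 `O=C1N(CCCCCCOc2ccc(Cl)cc2)CCN1c1ccncc1` gives > 25000 nM, which is a limit of the assay.
- compound 2 `Cc1ccc(OCCCCCCN2CCN(c3ccncc3)C2=O)cc1` gives > 25000 nM, also a limit.
- compound 3 `O=C1N(CCCCCCOc2cccc(Br)c2)CCN1c1ccncc1` gives > 25000 nM, again a limit.

All three compounds share one core and differ only in the group on the aromatic ring at the end of the six-carbon chain. For the measured compounds named here, every value so far sits at the limit of > 25000 nM in this assay, at which 3 of the 3 values shown sit, so no compound can be placed above or below another. The steps a step that the two limits leave unreadable from compound 1 to compound 2, a step that the two limits leave unreadable from compound 1 to compound 3 and a step that the two limits leave unreadable from compound 2 to compound 3 are therefore unreadable in size and direction.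

Compound 4 `CN(C)c1cccc(OCCCCCCN2CCN(c3ccncc3)C2=O)c1` has not yet been measured. It differs from compound 3 by dimethylamino in place of bromo on an aromatic carbon.

The measured steps bear on this change only in showing that exchanging one ring substituent for another has left every value at the limit. No step beyond the scatter is expected; the expected step is a number no higher from compound 3 to compound 4 (the limit leaves the size open). For compound 4 in this assay the estimate is 25000 nM, with a range from 10000 nM to 60000 nM.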

Compound 4, half-maximal cytotoxic concentration: > 25000 nM
Compound 4 gave a limit, no number (the forecaster's own chance of this, stated with the estimate: 80%); the middle value sits exactly at the limit.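

Compound 4 joins compound 1, compound 2 and compound 3 at a limit rather than a number in this assay, so no step among them can be read: the limit of > 25000 nM in this assay, at which 4 of the 4 values shown sit.

These compounds leave open whether any group on this aromatic ring would give a measurable value, and how the four would rank.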